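Swapping the side group on a potent macrocycle

A few compounds are considered here, and "the series" means these few. Any claim that something is new, unique, unknown or untested is made for them only; others in the source may bear on it.

Values in a functional assay on KB cells (Homo sapiens), with a stated time of 72 h (on this read-out higher numbers stand for weaker inhibition and lower numbers for stronger inhibition), so far:
Compound 1 `Cc1nc2cc([C@@H]3C[C@@H]4O[C@]4(C)CCC[C@H](C)[C@H](O)[C@@H](C)C(=O)C(C)(C)[C@@H](O)CC(=O)O3)ccc2s1` gives 0.09 nM
Compound 2 `C[C@H]1CCC[C@@]2(C)O[C@H]2C[C@@H](c2ccc3c(c2)ncn3C)OC(=O)C[C@H](O)C(C)(C)C(=O)[C@H](C)[C@H]1O` gives 0.46 nM
Compound 3 `Cc1nc2cc([C@@H]3C[C@@H]4O[C@]4(C)CCC[C@H](C)[C@H](O)[C@@H](C)C(=O)C(C)(C)[C@@H](O)CC(=O)O3)ccc2n1C` gives 0.38 nM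

Compound 3 gives 0.38 nM which is within the usual scatter of the number for compound 2. The lowest number of the three lies further off, with a 4.2-fold higher number from compound 1 to compound 3 (0.63 log units; beyond the scatter) as the step. Compound 4 `C/C(=C\c1ccccn1)[C@@H]1C[C@@H]2O[C@]2(C)CCC[C@H](C)[C@H](O)[C@@H](C)C(=O)C(C)(C)[C@@H](O)CC(=O)O1` replaces the group on the saturated ring carbon next to the ring oxygen (a group of 9 heavy atoms (8 carbon, 1 nitrogen; one six-membered aromatic ring with 1 hetero atom) in place of a group of 11 heavy atoms (9 carbon, 2 nitrogen; one five-membered aromatic ring with 2 hetero atoms, one six-membered aromatic ring of carbon only), on a saturated ring carbon). It brings one six-membered aromatic ring with 1 hetero atom and 1 double bond outside aromatic rings. Two measured swaps at this carbon bear on it, both modest: a 5.1-fold higher number from compound 1 to compound 2 (0.71 log units; beyond the scatter) and a 4.2-fold higher number from compound 1 to compound 3 (0.63 log units; beyond the scatter). Neither swap introduced such a group, so the guide is loose. The expected step is a 1.3-fold higher number from compound 3 to compound 4 (0.12 log units; within the scatter) which would stay within the scatter in this assay. The estimated value for compound 4 is 0.5 nM (expected range 0.15 nM to 1.6 nM).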

Compound 4, half-maximal inhibitory concentration: 0.3 nM
Compound 4: the middle estimate sits 1.7-fold (0.22 log units) above what was measured; the range from low to high includes it.
By their numbers in this assay, from the lowest: compound 1; then compounds 4, 3 and 2 (each within the scatter of the next).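

A side group with one six-membered aromatic ring and a double bond outside it, and no fused ring, matches the two fused groups that carry two nitrogens: a 1.3-fold lower number from compound 3 to compound 4 (0.10 log units; within the scatter) and a 1.5-fold lower number from compound 2 to compound 4 (0.19 log units; within the scatter) both stay within the scatter. Only the sulfur-containing fused group of compound 1 stands apart, with a 3.3-fold higher number from compound 1 to compound 4 (0.52 log units; beyond the scatter) beyond the scatter. Nothing measured here accounts for these numbers. Still open, from the compounds shown here alone, is how an amine or a carboxylic acid on that six-membered aromatic ring would fare, and whether a saturated chain could replace the double bond.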